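Amide nitrogen substitution in a fused pyrazole series

The source may hold more compounds than are shown below. What is called first, only, known or untested is meant among the compounds shown, and "the series" means these compounds.

Compound 1 `Cc1n[nH]c2c1C(c1ccc(N(C)C)cc1)C(C(N)=O)=C(N)N2` gives the lowest of the three measured numbers in a functional assay on HepG2 cells (Homo sapiens) for cytotoxicity, read by MTT assay, with a stated time of 48 h (on this read-out higher numbers stand for weaker inhibition and lower numbers for stronger inhibition), at 5280 nM. Compound 2 `Cc1n[nH]c2c1C(c1ccc(N(C)C)cc1)C(C(=O)NNC(N)=S)=C(N)N2` gives 6320 nM and compound 3 `Cc1n[nH]c2c1C(c1ccc(N(C)C)cc1)C(C(=O)O)=C(N)N2` gives 39700 nM. Compound 4 `Cc1n[nH]c2c1C(c1ccc(N(C)C)cc1)C(C(=O)N/N=C1/C(=O)Nc3ccccc31)=C(N)N2` differs from compound 1 by a group of 11 heavy atoms (8 carbon, 2 nitrogen, 1 oxygen; one five-membered non-aromatic ring with 1 hetero atom, one six-membered aromatic ring of carbon only) in place of a hydrogen atom, on an amide-type nitrogen. The step that bears on this is a 1.2-fold higher number from compound 1 to compound 2 (0.08 log units; within the scatter), where a group also entered on the same amide-type nitrogen. The step of a 7.5-fold higher number from compound 1 to compound 3 (0.88 log units; beyond the scatter) lies beyond the scatter but does not apply here, as the amino on the carbonyl carbon is kept in compound 4. No step beyond the scatter is therefore expected in this assay, the expected step being a 1.1-fold lower number from compound 1 to compound 4 (0.02 log units; within the scatter). Compound 4 is estimated at 5000 nM, with an expected range of 1500 nM to 16000 nM.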

Compound 4, half-maximal inhibitory concentration: 57900 nM
Compound 4: the middle estimate sits 12-fold (1.06 log units) below what was measured; the measured number lies above the stated range.
By their numbers in this assay, from the lowest: compounds 1 and 2 (each within the scatter of the next); then compounds 3 and 4 (each within the scatter of the next).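

Substitution on this amide-type nitrogen is not neutral in itself in this assay: with the group of 11 heavy atoms there is an 11-fold higher number from compound 1 to compound 4 (1.04 log units; beyond the scatter), and replacing the group in compound 2 gives a 9.2-fold higher number from compound 2 to compound 4 (0.96 log units; beyond the scatter). The outcome at this position therefore depends on which group enters, which the earlier substitution could not show. No measurement at hand accounts for these steps.

From the compounds shown here alone, it remains open whether a simpler group on the same nitrogen, such as methyl or phenyl, would read like compound 1 or like compound 4.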